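A few compounds are considered here, and "the series" means these few. Any claim that something is new, unique, unknown or untested is made for them only; others in the source may bear on it.

Measured so far in a functional assay on NCI-H460 cells (Homo sapiens) for antiproliferative activity, read by MTT assay, with a stated time of 72 h; on this read-out lower numbers stand for stronger inhibition and higher numbers for weaker inhibition:

compound 1, `CCN(CC)CCn1cnnc1-c1cc(Oc2ccc(NC(=O)Nc3cccc(C(F)(F)F)c3)cc2F)ccn1`: 9870 nM
compound 2, `CCN(CC)CCn1cnnc1-c1cc(Oc2ccc(NC(=O)Nc3ccc(F)c(F)c3)cc2F)ccn1`: 14900 nM
compound 3, `CCN(CC)CCn1cnnc1-c1cc(Oc2ccc(NC(=O)Nc3ccc(Cl)cc3Cl)cc2F)ccn1`: 5380 nM

All three compounds share one core and differ only in the aryl group attached to the urea nitrogen. Compound 2 stands at the highest number of the three, meaning the weakest inhibition. Its nearest neighbour is compound 1, its most distant is compound 3. The three measured steps read as follows: a 1.5-fold higher number from compound 1 to compound 2 (0.18 log units; within the scatter); a 1.8-fold lower number from compound 1 to compound 3 (0.26 log units; within the scatter); and a 2.8-fold lower number from compound 2 to compound 3 (0.44 log units; beyond the scatter). Only the last of these reaches beyond the usual scatter, and all of them concern the aryl group on the urea nitrogen.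

Compound 4, `CN(C)CCCn1cnnc1-c1cc(Oc2ccc(NC(=O)Nc3ccc(F)c(F)c3)cc2F)ccn1`, takes a different route. Compared with compound 2, the change is (dimethylamino)methyl in place of diethylamino on a saturated chain carbon, two bonds along the chain from an aromatic nitrogen. The urea end of the molecule is untouched. Among the measured compounds shown here, none of the measured steps touches the amine chain, so there is nothing in the measured compounds to suggest a shift in either direction. The sensible expectation is therefore no step beyond the scatter.

Compound 4 is thus estimated to give 14000 nM, with a range from 6000 nM to 35000 nM. This estimate means a 1.1-fold lower number from compound 2 to compound 4 (0.03 log units; within the scatter) in this assay.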

Compound 4, half-maximal inhibitory concentration: 1080 nM
For compound 4 the middle estimate is 13-fold (1.11 log units) above the measured one; the measured number lies below the stated range.
By their numbers in this assay, from the lowest: compound 4; then compounds 3, 1 and 2 (each within the scatter of the next, the first and the last beyond it).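

In this assay, 3-(dimethylamino)propyl in place of 2-(diethylamino)ethyl gives a 14-fold lower number from compound 2 to compound 4 (1.14 log units; beyond the scatter) and the amine chain proves to be a sensitive part of the molecule. Compound 1, compound 2 and compound 3 all carry the same chain, so they could not show this. Nothing available explains the size of this step.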